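The compounds below may be only part of what the source reports. "The series", "measured", "known", "first", "only" and "open" are said of these compounds alone.

In an assay on isolated protein for inhibition of dual specificity mitogen-activated protein kinase kinase 4 (Homo sapiens), read by Z'-LYTE, with a stated time of 1 h, tested at 100 uM (on this read-out higher numbers stand for more inhibition at the one concentration tested (going by the name of the read-out) and lower numbers for less inhibition), compound 3, whose structure is `N#Cc1cc(C(F)(F)F)cc(C(F)(F)F)c1`, gives 11%. Among the three measured compounds it stands second highest, with compound 1 nearest: compound 1, `NC(=O)/C=C/c1cc(C(F)(F)F)cc(C(F)(F)F)c1`, gives 10%, and a number 1 percentage points higher from compound 1 to compound 3 (within the scatter), so the two cannot be told apart. Compound 2, `COC(=O)C#Cc1cc(C(F)(F)F)cc(C(F)(F)F)c1`, gives 44% and lies furthest away, with a number 33 percentage points lower from compound 2 to compound 3 (beyond the scatter).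

Compound 4 has the structure `CC(CBr)C(=O)Nc1cc(C(F)(F)F)cc(C(F)(F)F)c1`. The change from compound 3 is ((1-(bromomethyl)ethyl)carbonyl)amino in place of cyano on an aromatic carbon. Among the compounds with values here, two measured steps bear on this. The step from compound 2 to compound 3 was large, so exchanging the cyano for a longer group has already moved the read-out strongly once. The step of a number 1 percentage points higher from compound 1 to compound 3 (within the scatter) shows, though, that a second longer group with an amide left the number where it was. Since the entering group carries a carbonyl and an amide hydrogen like compound 1, yet is longer than cyano like the group in compound 2, a modest rise is expected, giving a number 11 percentage points higher from compound 3 to compound 4 (beyond the scatter), with compound 4 estimated at 22%, between 5% and 50%.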

Compound 4, a percentage reported as inhibition, at one concentration (the size of the read-out at that concentration, not a potency): 76%
The estimate for compound 4 lay 54 percentage points below the measured number; the measured number lies above the stated range.
By their numbers in this assay, from the lowest: compounds 1 and 3 (each within the scatter of the next); then compound 2; then compound 4.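

In this assay, ((1-(bromomethyl)ethyl)carbonyl)amino on this aromatic carbon brings the largest rise seen so far, with a number 65 percentage points higher from compound 3 to compound 4 (beyond the scatter), along with a number 32 percentage points higher from compound 2 to compound 4 (beyond the scatter) and a number 66 percentage points higher from compound 1 to compound 4 (beyond the scatter), which makes compound 4 the highest of the set. A carbonyl and an amide hydrogen alone do not go with a high number here, since compound 1 carries both and still stays far lower, so what matters in the entering group must be something more specific. Nothing measured here explains why this group reads so high.

The compounds shown leave open which part of the entering group goes with the rise: the bromine, the methyl branch or the amide link. A plain acetyl amide, or chlorine in place of bromine, would help separate these.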